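This account rests on a few compounds, and the source may have more. Where it says the series, first, only, none or still open, it means among the compounds named here.

In a functional assay on PC-3 cells (Homo sapiens) for cytotoxicity, read by MTT assay, with a stated time of 72 h (on this read-out higher numbers stand for weaker inhibition of growth and lower numbers for stronger inhibition of growth), compound 1 `CCCOC(=O)Nc1ccc([Se]C#N)cc1` gives 47400 nM. Among the measured compounds shown here, the only other measured compound, compound 2 `O=C(Nc1ccc([Se][Se]c2ccc(NC(=O)OCc3ccc([N+](=O)[O-])cc3)cc2)cc1)OCc1ccc([N+](=O)[O-])cc1`, gives 27100 nM in this assay. For the measured compounds named here, of the two numbers, the one for compound 1 is the larger as written, but the gap to compound 2 falls within the usual scatter of repeated measurements, so the two compounds cannot be told apart on this evidence.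

Compound 3 `CCOC(=O)Nc1ccc([Se]C#N)cc1` differs from compound 1 in a single spot: hydrogen in place of methyl on a saturated chain carbon, two bonds along the chain from an oxygen next to a carbonyl group. This shortens the chain on the carbamate by one carbon while leaving the rest of the molecule, including the selenocyanate on the ring, untouched. Going by the values given here, no pair of measured compounds shows what such a shortening does in this assay, so there is no measured step to lean on. A change this small, removing one carbon from a flexible chain, is expected to shift the number little: the step from compound 1 to compound 3 is estimated at a 1.1-fold lower number from compound 1 to compound 3 (0.02 log units; within the scatter), which amounts to no change beyond the scatter in either direction. Compound 3 is therefore expected to give about 45000 nM in this assay, within a range from 20000 nM to 100000 nM.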

Compound 3, concentration for total growth inhibition: 39200 nM
Estimate against measurement, compound 3: 1.1-fold (0.06 log units) above; low and high end bracket the measured number.
By their numbers in this assay, from the lowest: compounds 2, 3 and 1 (each within the scatter of the next).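

In this assay, among the compounds shown here, the pair of compound 1 and compound 3 gives the first reading of a change in one place, since the earlier compounds offered no such pair: propoxy to ethoxy, with hydrogen in place of methyl on a saturated chain carbon, two bonds along the chain from an oxygen next to a carbonyl group, is a 1.2-fold lower number from compound 1 to compound 3 (0.08 log units; within the scatter). So, with the selenocyanate and the rest of the core of compound 1 left as they are, losing this one carbon from the chain gives no difference that can be told from the ordinary spread of repeat measurements. Nothing measured here bears on the reason for this result.

This is a single step, so it says nothing about how far such tolerance reaches along the chain, and a flat result for one carbon need not hold for larger changes. Still open, on these data alone, is what a methoxy or a longer chain such as butoxy would give in place of the propoxy, and whether an amine or a carboxylic acid carried on the chain would move the number beyond the scatter.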